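The compounds below may be only part of what the source reports. "The series", "measured", "known", "first", "only" and "open" are said of these compounds alone.

Measured so far:
Compound 1, `C[C@@H](NC(=O)c1ccc(C#Cc2ccccc2)cn1)C(C)(C)O`: 60.9%
Compound 2, `Cc1nc(C#Cc2ccc(C(=O)N[C@H](C)C(C)(C)O)nc2)cs1`: 66.6%

In a functional assay on HEK293 cells for positive allosteric modulation of metabotropic glutamate receptor 5 (Rattus norvegicus), read by fluorescence and calcium flux (on this read-out lower numbers stand for smaller maximal responses and higher numbers for larger maximal responses), compound 1 gives 60.9% and compound 2 gives 66.6%. For the measured compounds named here, compound 2 holds the higher of the two numbers, but the only step so far, a number 5.7 percentage points higher from compound 1 to compound 2 (within the scatter), stays within the scatter, so the two compounds cannot be told apart on this read-out.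

Compound 3, `C[C@@H](NC(=O)c1ccc(C#Cc2cccc(F)n2)cn1)C(C)(C)O`, has not been measured yet. It differs from compound 2 in one place: 6-fluoropyridin-2-yl in place of 2-methyl-1,3-thiazol-4-yl on a triple-bonded carbon. Going by the values given here, the one measured step that bears on this change is a number 5.7 percentage points higher from compound 1 to compound 2 (within the scatter), where one ring on the triple-bonded carbon was exchanged for another and the response did not move beyond the scatter. Among the compounds with values here, with only that step to go on, no change beyond the scatter is expected here either. Compound 3 is therefore expected to give about 63%, within a range from 50% to 77%. The expected step is a number 3.6 percentage points lower from compound 2 to compound 3 (within the scatter).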

Compound 3, largest response reached (reported as efficacy), in percent of the reference or control that the assay uses: 63%
Estimate against measurement, compound 3: no gap at the digits printed; measured number inside the range.
By their numbers in this assay, from the lowest: compounds 1, 3 and 2 (each within the scatter of the next).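

With this assay as the measure, the step to the new ring is a number 3.6 percentage points lower from compound 2 to compound 3 (within the scatter) and the step from the original ring is a number 2.1 percentage points higher from compound 1 to compound 3 (within the scatter) so a third ring on the triple-bonded carbon leaves the response where the first two put it. The comparison now covers a wider range of rings: phenyl, a five-membered aromatic ring with 2 hetero atoms, and a six-membered aromatic ring with 1 hetero atom that also carries fluorine cannot be told apart on this read-out. No measurement here explains why these exchanges make no visible difference.

Going by these compounds, all three groups at this place are single aromatic rings, so it remains open whether the response would hold with something other than such a ring. An amine or a longer chain on the triple-bonded carbon could show where this freedom ends.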